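The source may report more compounds than this note shows. Statements on the series, on what has been measured and on what is new or still open speak of the compounds shown alone.

Notes on the series. Going by the values given here, in an ADME assay on RAW264.7 cells (Mus musculus) for inhibition, read by MTT assay, with a stated time of 72 h, tested at 100 uM (a higher number here means more inhibition of growth at the concentration tested, a lower number less inhibition of growth), compound 1 `Cc1ccccc1/N=N/C(=N/NC(=O)c1cc(O)c(O)c(O)c1)c1ccccc1` gives 41.5%, the higher of the two numbers so far. Compound 2 `COc1ccc(/N=N/C(=N/NC(=O)c2cc(O)c(O)c(O)c2)c2ccccc2)cc1` gives 15%.

Compound 3 `O=C(N/N=C(/N=N/c1ccc([N+](=O)[O-])cc1)c1ccccc1)c1cc(O)c(O)c(O)c1` keeps the core of compound 1 but carries 4-nitrophenyl in place of 2-methylphenyl on a double-bonded nitrogen. Among the compounds with values here, only one measured step bears on this change: a number 26.5 percentage points lower from compound 1 to compound 2 (beyond the scatter). That step also removes 2-methylphenyl from the same place, and it is modest but beyond the scatter. Within the data shown here, no measured compound carries 4-nitrophenyl, and a single step shows neither how much of the drop comes from losing 2-methylphenyl nor how much depends on the group that enters.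

A lower number is therefore expected in this assay, with some allowance for the new group, and the estimated change is a number 19.5 percentage points lower from compound 1 to compound 3 (beyond the scatter). This expected step is somewhat smaller than the measured one, and its direction remains tentative. For compound 3 the estimated value is 22%, with an expected range from 5% to 45%.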

Compound 3, percent growth inhibition at one concentration: 34.6%
The estimate for compound 3 lay 12.6 percentage points below the measured number, within the range that was stated.
By their numbers in this assay, from the lowest: compound 2; then compounds 3 and 1 (each within the scatter of the next).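

In this assay, the step of a number 6.9 percentage points lower from compound 1 to compound 3 (within the scatter) shows that replacing 2-methylphenyl on this double-bonded nitrogen need not cost a clear amount of growth inhibition. The outcome at this place depends on the group that enters, at least for this pair of entering groups: the step of a number 19.6 percentage points higher from compound 2 to compound 3 (beyond the scatter) separates 4-nitrophenyl from 4-methoxyphenyl through nitro in place of methoxy on an aromatic carbon, with the rest of the structure unchanged. No measured evidence accounts for this difference between nitro and methoxy.

Going by these compounds alone, the three compounds leave open whether compound 2 is the exception or compound 1 and compound 3 are, since only three groups have been seen at this place and no plain phenyl serves as a reference. An amine or a carboxylic acid in place of nitro on an aromatic carbon would test whether the step between methoxy and nitro extends to other groups in this series.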